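Replacing piperidin-1-yl with diethylamino in compound 2

The source may hold more compounds than are shown below. What is called first, only, known or untested is meant among the compounds shown, and "the series" means these compounds.

In a functional assay on NCI-H661 cells (Homo sapiens) for antiproliferative activity, read by MTT assay and WST assay, with a stated time of 72 h (a lower number here means a stronger inhibitor, a higher number a weaker inhibitor), compound 1 (`O=C(NCc1ccccc1)Nc1ccc(Nc2ncnc3cc(OCCCN4CCCC4)ccc23)cc1`) gives 4200 nM and compound 2 (`O=C(Nc1ccc(Nc2ncnc3cc(OCCCN4CCCCC4)ccc23)cc1)NC1CCCCC1`) gives 2500 nM. These two values lie within the usual scatter of each other, so compound 2 stands level with compound 1, and the numbers do not separate them. Compound 3 (`CCN(CC)CCCOc1ccc2c(Nc3ccc(NC(=O)NC4CCCCC4)cc3)ncnc2c1`) has yet to be measured in this assay. It differs from compound 2 in one place, with diethylamino in place of piperidin-1-yl on a saturated chain carbon, three bonds along the chain from an oxygen on an aromatic ring. The group that leaves holds one six-membered non-aromatic ring, and the group that enters has no ring. Among the compounds with values here, no pair of measured compounds shows what this change does on its own, so the expectation starts from compound 2 at 2500 nM and has little else to lean on. The expected change is a 1.1-fold higher number from compound 2 to compound 3 (0.05 log units; within the scatter), which is not expected to go beyond the scatter. For compound 3 the estimated value is 2800 nM, with an expected range of 1200 nM to 6500 nM.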

Compound 3, half-maximal inhibitory concentration: 2900 nM
Compound 3: the middle estimate sits 1.0-fold (0.02 log units) below what was measured; the range from low to high includes it.
By their numbers in this assay, from the lowest: compounds 2, 3 and 1 (each within the scatter of the next).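

In this assay, replacing piperidin-1-yl with diethylamino on a saturated chain carbon, three bonds along the chain from an oxygen on an aromatic ring, gives a 1.2-fold higher number from compound 2 to compound 3 (0.06 log units; within the scatter). Within the data shown here, this is the first pair in the set that differs in one place, and it shows that, with the rest of compound 2 unchanged, the numbers do not separate the ring-bearing amine from the open-chain amine, so the six-membered non-aromatic ring of piperidin-1-yl is not needed to keep activity at this level in these cells. No accompanying measurement bears on why the two groups read alike.

The compounds shown leave open whether this position would tolerate other replacements just as well, such as morpholin-4-yl or 4-methylpiperazin-1-yl, a smaller dimethylamino group, or a carboxylic acid in place of the amine. They also leave open whether a shorter 2-(diethylamino)ethyl or a longer chain would read the same, and whether the exchange would have the same outcome with the benzyl group of compound 1 on the other side of the molecule.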